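The source may report more compounds than this note shows. Statements on the series, on what has been measured and on what is new or still open speak of the compounds shown alone.

Compound 1 `CCCCCCCCCCCCCCC[C@@H](O)[C@@H](N)[C@@H](C)O`: 19000 nM
Compound 2 `CCCCCCCCCCCCCCC[C@@H](O)[C@@H](N)C(C)C`: 18000 nM
Compound 3 `CCCCCCCCC[C@@H](O)[C@H](C)N`: 12000 nM

In a functional assay on T47D cells (Homo sapiens) for antiproliferative activity, read by sulforhodamine B assay, with a stated time of 48 h (a lower number here means a stronger inhibitor of growth, a higher number a weaker inhibitor of growth), the three numbers sit close together; compound 3 sits within the scatter of compound 2 and of compound 1. Among the measured compounds shown here, the only measured step, a 1.1-fold lower number from compound 1 to compound 2 (0.02 log units; within the scatter), changes the group next to the amine and says nothing about chain length. Compound 4 `CCCCCCCCCCCCCCC[C@@H](O)[C@H](C)N` differs from compound 3 by hexyl in place of hydrogen on a saturated chain carbon, ten or more bonds along the chain from an oxygen on a saturated carbon, bringing its chain to the length found in compound 1 and compound 2, which carry other head groups. For the measured compounds named here, no step tests this change directly, so no step beyond the scatter is expected, a 1.3-fold higher number from compound 3 to compound 4 (0.10 log units; within the scatter). Compound 4 is therefore estimated at 15000 nM, within 7000 nM to 32000 nM.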

Compound 4, concentration for 50% growth inhibition: 900 nM
Estimate against measurement, compound 4: 17-fold (1.22 log units) above; the measured number lies below the stated range.
By their numbers in this assay, from the lowest: compound 4; then compounds 3, 2 and 1 (each within the scatter of the next).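

Chain length matters here after all: hexyl in place of hydrogen on a saturated chain carbon gives a 13-fold lower number from compound 3 to compound 4 (1.12 log units; beyond the scatter) in this assay. At this chain length the group on the saturated chain carbon bound to an amine nitrogen also counts: methyl in place of isopropyl gives a 20-fold lower number from compound 2 to compound 4 (1.30 log units; beyond the scatter), and methyl in place of 1-hydroxyethyl gives a 21-fold lower number from compound 1 to compound 4 (1.32 log units; beyond the scatter). Nothing measured here explains these steps. Still open, as far as these compounds go, is whether a longer chain would lower the number further, and how a carboxylic acid in place of the amine would fare.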